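The source may report more compounds than this note shows. Statements on the series, on what has been measured and on what is new or still open speak of the compounds shown alone.

In a functional assay on IMR-32 cells with melanin-concentrating hormone receptor 1 (Homo sapiens) as the target, read by fluorescence (a lower number here means a stronger inhibitor, a higher number a weaker inhibitor), compound 1 `Nc1ccc2cccc(OCC3CCCC3)c2n1` gives 2290 nM. Compound 2 `CC(CC(C)(C)C)Oc1cccc2ccc(N3CCCCC3)nc12` reaches only a limit of this assay, > 10000 nM, so for compound 2 there is no number, just a limit, and this is where it stands: the limit of > 10000 nM in this assay, at which 1 of the 2 values shown sits. Compound 3 `CC(CC(C)(C)C)Oc1cccc2cccnc12` has not been measured. Going from compound 2 to compound 3 puts (hydrogen in place of piperidin-1-yl on an aromatic carbon). Without a measured step of this kind, the change is expected to move potency a step that the limit leaves unreadable from compound 2 to compound 3, with no clear direction beyond the scatter. For compound 3 the estimate in this assay is 12000 nM, within 3000 nM to 50000 nM.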

Compound 3, half-maximal inhibitory concentration: > 10000 nM
Compound 3: only a limit was reported; the forecaster's own chance of this, stated with the estimate: 60%; the middle value does not contradict the limit.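

Going by these compounds alone, compound 2 and compound 3 both reach only a limit of this assay, not a number, so no step between them can be read: the limit of > 10000 nM in this assay, at which 2 of the 3 values shown sit. The compounds shown leave open whether hydrogen in place of piperidin-1-yl changes potency at all, in either direction.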